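Notes on compound 3: trifluoromethyl in place of chloro

A few compounds are considered here, and "the series" means these few. Any claim that something is new, unique, unknown or untested is made for them only; others in the source may bear on it.

The series is read in a functional assay on UACC-257 cells (Homo sapiens) for inhibition, read by sulforhodamine B assay, with a stated time of 48 h; on this read-out lower numbers stand for higher toxicity in this test and higher numbers for lower toxicity in this test. Compound 1 `COc1cc(-c2nn(-c3cccc(NC(=O)Nc4ccc(Cl)c(Cl)c4)c3)cc2-c2ccncc2)ccc1Cl` gives in this assay only a limit, > 50000 nM. Compound 2 `O=C(Nc1cccc(-n2cc(-c3ccncc3)c(-c3ccc(Cl)c(O)c3)n2)c1)Nc1ccc(Cl)c(Cl)c1` likewise gives only a limit, > 32500 nM. The step that the two limits leave unreadable from compound 1 to compound 2, hydrogen in place of methyl on an oxygen on an aromatic ring, cannot be sized, since both ends rest on limits, the limit of > 32500 nM in this assay, at which 1 of the 2 values shown sits, and (the limit of > 50000 nM in this assay, at which 1 of the 2 values shown sits); compound 2 thus stands among two values that are both limits and carries no number of its own. Compound 3 `O=C(Nc1cccc(-n2cc(-c3ccncc3)c(-c3ccc(Cl)c(O)c3)n2)c1)Nc1ccc(Cl)c(C(F)(F)F)c1` differs from compound 2 by trifluoromethyl in place of chloro on an aromatic carbon, so 3,4-dichlorophenyl becomes 4-chloro-3-(trifluoromethyl)phenyl. No measured step in the series touches this change, and the single step shown is itself unreadable, so no size or direction can be drawn for it; the expectation is a value not beyond the scatter from the limit of compound 2. Compound 3 is therefore expected to give 40000 nM in this assay, range 15000 nM to 100000 nM, a step that the limit leaves unreadable from compound 2 to compound 3 that most likely again reports only a limit.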

Compound 3, concentration lethal to 50% of the cells: 8390 nM
For compound 3 the middle estimate is 4.8-fold (0.68 log units) above the measured one, outside the stated range (below it).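

In this assay, among these compounds, trifluoromethyl in place of chloro gives an at least 3.8-fold lower number from compound 2 to compound 3 (0.58 log units; beyond the scatter), the first readable step and the first move at this ring, where the earlier step changed only the methyl on an oxygen on the other aromatic ring. The carbon ortho to a chloro group on the 3,4-dichlorophenyl ring is thus a place where one exchange, with the chloro group kept, shifts the read-out towards higher toxicity in this test. The size of the step is only a minimum, since one end of it rests on a limit: the limit of > 32500 nM in this assay, at which 1 of the 3 values shown sits.

The compounds shown leave open whether a nitrile or a carboxylic acid on this carbon would shift the read-out in the same way. They also leave open whether the same exchange would hold with the methyl on the oxygen kept, as in compound 1.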